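Chlorophenyl in place of anilino on a pyridazinone cyanoguanidine

This account rests on a few compounds, and the source may have more. Where it says the series, first, only, none or still open, it means among the compounds named here.

Measured compounds:
compound 1, `C/N=C(/NC#N)NCCCCn1nc(N(C)C)ccc1=O`, 26.3%
compound 2, `C/N=C(/NC#N)NCCCCn1nc(N2CCCC2)ccc1=O`, -1%
compound 3, `C/N=C(/NC#N)NCCCCn1nc(Nc2ccccc2)ccc1=O`, 24.4%

In a functional assay on the whole organism with Rattus norvegicus as the target, at a dose of 100 mg/kg (a lower number here means less inhibition, a higher number more inhibition at the dose given (going by the name of the read-out)), compound 3 stands second highest of the three numbers: its gap to compound 1 is within the scatter, while compound 2 is clearly lower, as a number 25.4 percentage points higher from compound 2 to compound 3 (beyond the scatter) shows. Compound 4, `C/N=C(/NC#N)NCCCCn1nc(-c2ccc(Cl)cc2)ccc1=O`, differs from compound 3 in one place: 4-chlorophenyl in place of anilino on an aromatic carbon.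

The measured steps all swap one nitrogen-linked group for another on that aromatic carbon. a number 27.3 percentage points lower from compound 1 to compound 2 (beyond the scatter) and a number 25.4 percentage points higher from compound 2 to compound 3 (beyond the scatter) show that such a swap can move the number modestly, whereas a number 1.9 percentage points lower from compound 1 to compound 3 (within the scatter) shows no change beyond the scatter. None of these steps replaces a nitrogen-linked group with a carbon-linked aromatic ring, so the step to compound 4 is not directly covered.

Given that the measured steps, as a number 27.3 percentage points lower from compound 1 to compound 2 (beyond the scatter) shows, can move the read-out only modestly, compound 4 is expected to give a number near the spread of the measured values, with an estimated step of a number 12.4 percentage points lower from compound 3 to compound 4 (beyond the scatter). Compound 4 is estimated at 12%, within -8% to 32%.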

Compound 4, a percentage reported as inhibition, in the whole organism at one dose (the size of the read-out at that dose, not a potency): 51%
For compound 4 the middle estimate is 39 percentage points below the measured one, and the stated range ends below it.
By their numbers in this assay, from the lowest: compound 2; then compounds 3 and 1 (each within the scatter of the next); then compound 4.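

In this assay, a carbon-linked aryl group is accepted on this aromatic carbon and gives a higher number than any of the nitrogen-linked groups: 4-chlorophenyl in place of anilino (a number 26.6 percentage points higher from compound 3 to compound 4 (beyond the scatter)), of dimethylamino (a number 24.7 percentage points higher from compound 1 to compound 4 (beyond the scatter)) and of pyrrolidin-1-yl (a number 52 percentage points higher from compound 2 to compound 4 (beyond the scatter)). Anilino and 4-chlorophenyl have the same heavy-atom count and each carries one six-membered aromatic ring of carbon only, so this step changes the atoms around that ring, with the hydrogen-bond donor and acceptor counted for anilino absent from 4-chlorophenyl. Nothing measured here accounts for the rise.

The compounds shown leave open whether the rise belongs to the chlorine or to the loss of the linking nitrogen, a question that a plain phenyl group on this carbon would separate. On these data alone, how a 4-methoxyphenyl group or a pyridyl ring would fare here also remains open.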